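The source may hold more compounds than are shown below. What is called first, only, known or untested is meant among the compounds shown, and "the series" means these compounds.

Compound 2 `CCCCc1nnc(O)n2c(CCC)nc(C)c12` is one of three close relatives examined in a functional assay for inhibition, with Homo sapiens as the target; a lower number here means a stronger inhibitor, a higher number a weaker inhibitor. In this assay compound 2 gives only > 48000 nM, which is a limit of the assay rather than a measured number. Compound 1 `CCCc1nc(C)c2c(C(C)C)nnc(O)n12` differs from compound 2 in one side chain, and in this assay compound 1 likewise reaches only the limit > 48000 nM. The step that the two limits leave unreadable from compound 1 to compound 2 therefore cannot be read, as both ends sit at the same limit. Compound 3 `CSc1nncc2c(C)nc(C)n12`, built on a related core, also returns only the limit > 48000 nM in this assay. What the three results share is the limit of > 48000 nM in this assay, at which 3 of the 3 values shown sit, so none of them shows measurable inhibition.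

Compound 4 `CCCc1nnc(O)n2c(CCC)nc(C)c12` has not yet been measured. It differs from compound 2 by hydrogen in place of methyl on a saturated chain carbon, three bonds along the chain from an aromatic carbon, which, read one bond further out, is butyl to propyl. Among the measured compounds shown here, the only measured step of a similar kind, a step that the two limits leave unreadable from compound 1 to compound 2, gives no size, so there is nothing to point toward either a gain or a loss. With every value at the limit, compound 4 is expected to behave the same way, and the step that the limit leaves unreadable from compound 2 to compound 4 is expected to be none beyond the scatter. The estimate for compound 4 is therefore 70000 nM, with a range from 20000 nM to 250000 nM, and most likely reported again only as a limit.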

Compound 4, half-maximal inhibitory concentration: 16000 nM
Beside the measured number, compound 4's estimate is 4.4-fold (0.64 log units) above it, and the stated range ends above it.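

In this assay, compound 4 is the only one of these compounds whose inhibition can be read as a number, while the others stay at a limit: the limit of > 48000 nM in this assay, at which 3 of the 4 values shown sit. Changing butyl to propyl on the aromatic carbon gives an at least 3.0-fold lower number from compound 2 to compound 4 (0.47 log units; beyond the scatter), so the chain at this carbon does affect the read-out, which the unreadable step between the two earlier limits could not show. Propyl in place of isopropyl on that carbon gives an at least 3.0-fold lower number from compound 1 to compound 4 (0.47 log units; beyond the scatter), so in these compounds the straight chain and the branched chain of the same name-length do not read alike, and chain size alone does not settle the result.

From the compounds shown here alone, both steps start from a limit, so their full size remains unknown, and a single measured value cannot show whether propyl is a peak or simply one point on a longer trend. Also open, going by these compounds, is how an ethyl or a methyl on this carbon would compare, and whether a chain ending in an amine or a carboxylic acid would be tolerated there.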